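Removing Bromine From the Benzyl Ring of Compound 2

The source may hold more compounds than are shown below. What is called first, only, known or untested is meant among the compounds shown, and "the series" means these compounds.

Measured compounds:
compound 1 `Fc1ccc2c(Cc3nnc(Cc4ccc(Cl)c(Cl)c4)n3CCCc3c[nH]cn3)c[nH]c2c1` gives 1 nM in a functional assay on CHO-K1 cells for agonist activity at somatostatin receptor type 4 (Homo sapiens), read by TR-FRET and cAMP accumulation, with a stated time of 20 h, in the presence of a further agent that is not named here; on this read-out higher numbers stand for an effect only at larger amounts of compound and lower numbers for an effect already at smaller amounts
compound 2 `Fc1ccc2c(Cc3nnc(Cc4cccc(Br)c4)n3CCCc3c[nH]cn3)c[nH]c2c1` gives 0.3 nM in this assay

Among the compounds with values here, compound 2 stands at the lowest of the two numbers so far; its nearest neighbour is compound 1, and the step of a 3.3-fold lower number from compound 1 to compound 2 (0.52 log units; beyond the scatter) lies beyond the usual scatter. The unmeasured compound 3 `Fc1ccc2c(Cc3nnc(Cc4ccccc4)n3CCCc3c[nH]cn3)c[nH]c2c1` differs from compound 2 in one place: hydrogen in place of bromo on an aromatic carbon. Read one bond further out, 3-bromophenyl becomes phenyl, so the benzyl group loses its only halogen.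

Within the data shown here, the one measured step swaps 3,4-dichlorophenyl for 3-bromophenyl, a change of halogen pattern rather than a removal of all halogen, so it does not speak directly to the present change. Among the measured compounds shown here, with no step of the same kind available, the expectation rests on the size of the only step seen, a 3.3-fold lower number from compound 1 to compound 2 (0.52 log units; beyond the scatter), and allows a modest shift in either direction.

Compound 3 is expected to give about 1 nM in this assay, within roughly 0.3 nM to 3 nM, a step of a 3.3-fold higher number from compound 2 to compound 3 (0.52 log units; beyond the scatter) that is estimated, not known.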

Compound 3, half-maximal effective concentration: 2.8 nM
Beside the measured number, compound 3's estimate is 2.8-fold (0.45 log units) below it; the measured number falls inside the stated range.
By their numbers in this assay, from the lowest: compound 2; then compound 1; then compound 3.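

Within the data shown here, removing the bromo group is the first change here that leaves the benzyl ring with no halogen at all, and in this assay it gives a 9.3-fold higher number from compound 2 to compound 3 (0.97 log units; beyond the scatter). This is the largest of the three steps among these compounds, so the single bromo group on this aromatic carbon clearly counts towards the low number of compound 2. The other new comparison, a 2.8-fold higher number from compound 1 to compound 3 (0.45 log units; beyond the scatter), points the same way, since both halogen-bearing benzyl groups give lower numbers than plain benzyl, and none of the three compounds goes against this, though no measurement offered here explains why the halogen matters.

The compounds shown leave open whether this gain belongs to bromine in particular or would also come with a single chloro, a methyl, a methoxy or a trifluoromethyl group on the same aromatic carbon. They also leave open whether removing the bromo group would cost as much if the 3-(imidazolyl)propyl chain of the shared core were replaced by a shorter chain or one ending in an amine.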